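A few compounds are considered here, and "the series" means these few. Any claim that something is new, unique, unknown or untested is made for them only; others in the source may bear on it.

Three compounds have been measured in a functional assay on NCI-H1975 cells (Homo sapiens) for antiproliferative activity, read by CCK-8 assay, with a stated time of 72 h; on this read-out higher numbers stand for weaker inhibition of growth and lower numbers for stronger inhibition of growth:

compound 1 `CCC1C(=O)N(C)c2cnc(Nc3ccc(S(=O)(=O)NC)cc3)nc2N1c1ccn(C)n1`: 18800 nM
compound 2 `CCC1C(=O)N(C)c2cnc(Nc3ccc(S(=O)(=O)NCC(C)C)cc3)nc2N1c1ccn(C)n1`: 15000 nM
compound 3 `CCCCNS(=O)(=O)c1ccc(Nc2ncc3c(n2)N(c2ccn(C)n2)C(CC)C(=O)N3C)cc1`: 4120 nM

Compound 3 has the lowest number of the three, and its steps to both others lie beyond the scatter. Compound 4 `CCC1C(=O)N(C)c2cnc(Nc3ccc(S(=O)(=O)NCCCO)cc3)nc2N1c1ccn(C)n1` differs from it by a single change: hydroxy in place of methyl on a saturated chain carbon, three bonds along the chain from a sulfonamide nitrogen. This is hydroxy in place of methyl on a saturated chain carbon, three bonds along the chain from a sulfonamide nitrogen, so butyl becomes 3-hydroxypropyl. Among the compounds with values here, no measured step tests a hydroxy group directly. The nearest evidence comes from the changes to the same chain: a 4.6-fold lower number from compound 1 to compound 3 (0.66 log units; beyond the scatter), a 3.6-fold lower number from compound 2 to compound 3 (0.56 log units; beyond the scatter) and a 1.3-fold lower number from compound 1 to compound 2 (0.10 log units; within the scatter). The two modest steps both end at compound 3, so its number may depend on the exact chain. A modest step towards a higher number is therefore expected in this assay, of about the size of those two steps, though the direction is uncertain. The expected step is a 2.2-fold higher number from compound 3 to compound 4 (0.34 log units; beyond the scatter). Compound 4 is estimated at 9000 nM, with an expected range of 3500 nM to 20000 nM.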

Compound 4, concentration for 50% growth inhibition: 25800 nM
The estimate for compound 4 lay 2.9-fold (0.46 log units) below the measured number; measured number outside the range, above it.
By their numbers in this assay, from the lowest: compound 3; then compounds 2, 1 and 4 (each within the scatter of the next).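

In this assay, hydroxy in place of methyl on a saturated chain carbon, three bonds along the chain from a sulfonamide nitrogen, gives a 6.3-fold higher number from compound 3 to compound 4 (0.80 log units; beyond the scatter) and so turns butyl into 3-hydroxypropyl. The new compound does not keep the standing of the butyl compound: it lies level with the other two, with a 1.7-fold higher number from compound 2 to compound 4 (0.24 log units; within the scatter) and a 1.4-fold higher number from compound 1 to compound 4 (0.14 log units; within the scatter), so the low number of compound 3 does not survive this one-atom exchange. Nothing given here accounts for the size of this step.

The compounds shown leave open whether the low number belongs to butyl alone or would also appear with pentyl or another longer chain. They also leave open how a methoxy group or an amine in place of that methyl would read.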